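The source may report more compounds than this note shows. Statements on the series, on what has been measured and on what is new or still open speak of the compounds shown alone.

Measured compounds:
compound 1, `COc1cc(-c2nnc(SCc3cccc(Br)c3)o2)ccc1O`, 382000 nM
compound 2, `COc1cc(-c2nnc(SCc3c(F)cccc3F)o2)ccc1O`, 575000 nM

Both compounds were tested in an ADME assay on cells (Mus musculus, strain BALB/c) for cytotoxicity, read by MTT assay, with a stated time of 24 h; a higher number here means that more compound is tolerated, a lower number that less compound is tolerated. Compound 2 gives 575000 nM, the highest of the two numbers; its nearest neighbour is compound 1, which gives 382000 nM, and the step of a 1.5-fold higher number from compound 1 to compound 2 (0.18 log units; within the scatter) lies within the scatter. The unmeasured compound 3, `COc1cc(-c2nnc(SCc3ccc(F)cc3F)o2)ccc1O`, keeps the whole shared core and the sulfur-linked chain and differs from compound 2 only in the ring at the end of that chain: 2,4-difluorophenyl in place of 2,6-difluorophenyl on a saturated chain carbon bound to a sulfur. For the measured compounds named here, the one measured step that bears on this change is a 1.5-fold higher number from compound 1 to compound 2 (0.18 log units; within the scatter), in which one ring on the saturated chain carbon bound to a sulfur was replaced by another and the number stayed within the scatter. Compound 3 keeps the same two fluorines on the same ring, so no step beyond the scatter is expected in this assay. Compound 3 is therefore estimated at 500000 nM, with a range from 250000 nM to 1000000 nM. The step from compound 2 that this estimate means is a 1.2-fold lower number from compound 2 to compound 3 (0.06 log units; within the scatter).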

Compound 3, half-maximal cytotoxic concentration: 520000 nM
Compound 3: the middle estimate sits 1.0-fold (0.02 log units) below what was measured; measured number inside the range.
By their numbers in this assay, from the lowest: compounds 1, 3 and 2 (each within the scatter of the next).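

Moving one fluorine within the ring, with 2,4-difluorophenyl in place of 2,6-difluorophenyl on a saturated chain carbon bound to a sulfur, gives a 1.1-fold lower number from compound 2 to compound 3 (0.04 log units; within the scatter) in this assay, and the same ring compared with the 3-bromophenyl ring gives a 1.4-fold higher number from compound 1 to compound 3 (0.13 log units; within the scatter). The earlier compounds offered only one step at this position, whereas three different rings can now be compared, and every step among them stays within the scatter, so neither the choice of halogen nor the place of the fluorines among these three rings gives a readable difference in how much compound the cells tolerate. Nothing shown here offers an explanation for this lack of a readable difference.

Going by these compounds, all three compounds carry a halogen-bearing phenyl ring at this position, so it remains open whether an amine, a carboxylic acid or a longer chain on the saturated chain carbon bound to a sulfur would shift the number beyond the scatter. The shared core is also the same in all three compounds, which leaves open how much of the tolerated level depends on that core rather than on the ring at the end of the chain.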